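Changing the para substituent on the benzamide ring

A few compounds are considered here, and "the series" means these few. Any claim that something is new, unique, unknown or untested is made for them only; others in the source may bear on it.

Measured so far:
compound 1, `CCN(CC)c1cc2[nH]c(C3CCCCC3)nc2cc1NC(=O)c1ccc(F)cc1F`, > 100 ug/mL
compound 2, `CCN(CC)c1cc2[nH]c(C3CCCCC3)nc2cc1NC(=O)c1cnccn1`, > 100 ug/mL
compound 3, `CCN(CC)c1cc2[nH]c(C3CCCCC3)nc2cc1NC(=O)c1ccc(N(C)C)cc1`, "not determined" (no result reported)

In an ADME assay on Vero cells (Chlorocebus sabaeus) for cytotoxicity, read by resazurin assay, with a stated time of 3 days (a higher number here means a weaker inhibitor, a lower number a stronger inhibitor), compound 1 reaches only the limit of the assay, > 100 ug/mL. Compound 2 likewise reaches only the limit, > 100 ug/mL. The step that the two limits leave unreadable from compound 1 to compound 2 therefore cannot be read, because both values sit at the limit of > 100 ug/mL in this assay, at which 2 of the 3 values shown sit. For compound 3 no result is recorded in this assay, so its standing on the numbers is open.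

Compound 4, `CCc1ccc(C(=O)Nc2cc3nc(C4CCCCC4)[nH]c3cc2N(CC)CC)cc1`, differs from compound 3 by ethyl in place of dimethylamino on an aromatic carbon. For the measured compounds named here, no measured step bears directly on this change, and the only two measured values are both limits, so no direction or size of step can be drawn from them; the expectation rests on the shared core of compounds 1 and 2 showing no measurable cytotoxicity. Compound 4 is expected to behave in the same way, with an estimate of 100 ug/mL, likely between 50 ug/mL and 200 ug/mL.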

Compound 4, half-maximal inhibitory concentration: > 100 ug/mL
Compound 4: only a limit was reported; the forecaster's own chance of this, stated with the estimate: 75%; the middle value lies on the limit itself.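

In this assay compound 4 gives > 100 ug/mL, which is a limit and not a number. The steps to compound 4 from compound 1 and from compound 2 cannot be read, because both ends of each step sit at one shared value: the limit of > 100 ug/mL in this assay, at which 3 of the 4 values shown sit.

The compounds shown leave open how compound 1, compound 2 and compound 4 rank against one another, and where compound 3 stands.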